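The compounds below may be only part of what the source reports. "The series", "measured", "known", "first", "only" and "open" are said of these compounds alone.

Compound 1 `O=C(O)C[C@H](NC(=O)CCCCc1ccc2c(n1)NCCC2)c1cnc2ccccc2c1`: 65%
Compound 2 `O=C(O)C[C@H](NC(=O)CCCCc1ccc2c(n1)NCCC2)c1ccc2c(c1)OCC2`: 99%

In an in vivo ADME assay on the whole organism for pharmacokinetics, with Canis familiaris (Canis lupus familiaris) as the target (a lower number here means that a smaller share of the oral dose reaches the circulation, a higher number that a larger share of the oral dose reaches the circulation), compound 2 stands highest of the two measured compounds, at 99%. Compound 3 `O=C(O)C[C@H](NC(=O)CCCCc1ccc2c(n1)NCCC2)c1cccc(F)c1` differs from it at one place: a group of 7 heavy atoms (6 carbon, 1 fluorine; one six-membered aromatic ring of carbon only) in place of a group of 9 heavy atoms (8 carbon, 1 oxygen; one five-membered non-aromatic ring with 1 hetero atom, one six-membered aromatic ring of carbon only), on a saturated chain carbon bound to an amide-type nitrogen and a saturated chain carbon. Among the compounds with values here, the only measured step at that place is a number 34 percentage points higher from compound 1 to compound 2 (beyond the scatter), a large one. It shows that this place can matter, but it does not cover the 3-fluorophenyl group. With compound 2 already at 99%, a moderate fall is expected, although a large one cannot be excluded. The expected change is a number 24 percentage points lower from compound 2 to compound 3 (beyond the scatter). For compound 3 the estimated value in this assay is 75%, with an expected range of 50% to 98%.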

Compound 3, oral bioavailability: 81%
Compound 3: the middle estimate sits 6 percentage points below what was measured, and the stated range covers the measured number.
By their numbers in this assay, from the lowest: compound 1; then compound 3; then compound 2.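

With 3-fluorophenyl on the saturated chain carbon, this assay shows a number 18 percentage points lower from compound 2 to compound 3 (beyond the scatter), and also a number 16 percentage points higher from compound 1 to compound 3 (beyond the scatter). This places a group with one six-membered aromatic ring of carbon only between the two groups with two rings, so at this position, a second ring is not needed for a value above that of compound 1. No measurement given here accounts for this order. From the compounds shown here alone, what remains open is how a plain phenyl group or a pyridine ring would compare with 3-fluorophenyl, and whether chlorine could take the place of fluorine with a similar result.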